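Fluoro for trifluoromethoxy on the aryl amide of compound 1

The source may hold more compounds than are shown below. What is called first, only, known or untested is meant among the compounds shown, and "the series" means these compounds.

Compound 1, `CC(C)N(C(=O)CN1C=CN(c2ccccc2)C(=O)C(Cc2n[nH]c3ccccc23)C1=O)c1ccc(OC(F)(F)F)cc1`, is the reference point of this set. In a functional assay on CHO cells for agonist activity at Melanocortin receptor 4 (Homo sapiens), read by a luciferase reporter, with a stated time of 4 h (a higher number here means that more compound is needed for the effect, a lower number that less compound is needed), compound 1 gives 151 nM, the lowest number among the three measured compounds, and both of the others lie beyond the usual scatter from it. Compound 2, `COc1ccc(N(C(=O)CN2C=CN(c3ccccc3)C(=O)[C@H](Cc3n[nH]c4ccccc34)C2=O)C(C)C)cc1`, which carries a methoxy on the same aryl amide and a defined stereocentre, gives 339 nM in this assay. Compound 3, `CC(C)N(C(=O)CN1C=CN(c2ccccc2)C(=O)[C@H](Cc2n[nH]c3cc(F)ccc23)C1=O)c1ccccc1`, with an unsubstituted phenyl on the amide nitrogen and a fluoro on the indazole, gives 1260 nM in this assay. Within the data shown here, no pair among the measured compounds differs in a single place, so no isolated step is available.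

Compound 4, `CC(C)N(C(=O)CN1C=CN(c2ccccc2)C(=O)C(Cc2n[nH]c3ccccc23)C1=O)c1ccc(F)cc1`, is the next compound in this assay. Its change from compound 1 is fluoro in place of trifluoromethoxy on an aromatic carbon.

The measured numbers show that removing or shrinking the group on the aryl amide has gone with a higher number in this assay, though neither comparison is a clean single change. On that basis a modest rise in the number is expected for compound 4, a 2.3-fold higher number from compound 1 to compound 4 (0.37 log units; beyond the scatter), the step from compound 1 being expected to fall near or a little beyond the scatter. Compound 4 is therefore estimated at 350 nM in this assay, with a range of 150 nM to 900 nM.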

Compound 4, half-maximal effective concentration: 282 nM
Compound 4: the middle estimate sits 1.2-fold (0.09 log units) above what was measured; the measured number falls inside the stated range.
By their numbers in this assay, from the lowest: compounds 1, 4 and 2 (each within the scatter of the next, the first and the last beyond it); then compound 3.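

Among these compounds, the first single-place step sits at this aromatic carbon, para to a large group: in this assay the exchange gives a 1.9-fold higher number from compound 1 to compound 4 (0.27 log units; within the scatter). Trifluoromethoxy, with 5 heavy atoms and 1 hydrogen-bond acceptor, can therefore give way to fluoro, with 1 heavy atom and 0 hydrogen-bond acceptors, without a difference that can be read in this assay, which the earlier compounds could not show because each of those comparisons involved more than one place. No measurement in hand bears on why these two compounds cannot be told apart here.

From the compounds shown here alone, what an amine, a carboxylic acid or a longer alkoxy chain at this carbon would do to the number remains open, as does the result of leaving only hydrogen there on the otherwise unchanged core of compound 1. The methoxy of compound 2 and the unsubstituted phenyl of compound 3 also remain unplaced against this step, as each of those compounds differs from compound 1 in more than one place.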